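This account rests on a few compounds, and the source may have more. Where it says the series, first, only, none or still open, it means among the compounds named here.

Measured compounds:
Compound 1 `CCCOP(=O)(O)OCCSC(=S)N1CCCCC1` in a functional assay on PC-3 cells (Homo sapiens) for inhibition, read by MTT assay, with stated times of 18 h and 4 h (on this read-out higher numbers stand for weaker inhibition and lower numbers for stronger inhibition), gives > 100000 nM, a limit of the assay.
Compound 2 `CCCCCCOP(=O)(O)OCCSC(=S)N1CCCCC1` in this assay gives > 100000 nM, a limit of the assay.
Compound 3 `CCCCCCOP(=O)(O)OCCSC(=S)N1CCN(C)CC1` in this assay gives > 100000 nM, a limit of the assay.

The change hydrogen in place of propyl on a saturated chain carbon, three bonds along the chain from an oxygen on an unsaturated carbon was made between measured compounds, with a step that the two limits leave unreadable from compound 2 to compound 1. The two cores differ by 4-methylpiperazin-1-yl in place of piperidin-1-yl on a thiocarbonyl carbon, and that step is a step that the two limits leave unreadable from compound 2 to compound 3. Compound 4 `CCCOP(=O)(O)OCCSC(=S)N1CCN(C)CC1` is not yet measured; it differs from compound 3 by hydrogen in place of propyl on a saturated chain carbon, three bonds along the chain from an oxygen on an unsaturated carbon, at a place worded the same as before, so this is the same change applied to the other core. Because (the limit of > 100000 nM in this assay, at which 3 of the 3 values shown sit), there is no readable number to carry across. The step from compound 3 to compound 4 is expected to be a step that the limit leaves unreadable from compound 3 to compound 4, resting on compound 3 at > 100000 nM and compound 1 at > 100000 nM. Compound 4 is thus estimated at 200000 nM in this assay, most likely reported again only as a limit.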

Compound 4, half-maximal inhibitory concentration: > 100000 nM
Compound 4 was reported as a limit; the forecaster's own chance of this, stated with the estimate: 85%; the middle value lies beyond the limit too.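

In this assay no step can be read between compound 3 and compound 4, as both are limits: the limit of > 100000 nM in this assay, at which 4 of the 4 values shown sit.
Left open is what size the change from propyl to hydrogen has in this assay on values that are readable numbers.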